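The source may report more compounds than this note shows. Statements on the series, on what has been measured and on what is new or still open speak of the compounds shown alone.

Working notes on the series. Going by the values given here, in a functional assay on MCF7 cells (Homo sapiens) for cytotoxicity, read by MTT assay, with a stated time of 24 h (a lower number here means a stronger inhibitor, a higher number a weaker inhibitor), compound 1 (`CCCCc1nc(Cl)c(C=O)n1CCCOc1cc2c(Nc3cccc(I)c3)ncnc2cc1OC`) gives 3000 nM as the lower of the two numbers so far, and compound 2 (`CCCCc1nc(Cl)c(C=O)n1CCCOc1cc2c(Nc3cccc(F)c3)ncnc2cc1OC`) gives 12000 nM in the same read-out. Compound 3 (`CCCCc1nc(Cl)c(CO)n1CCCOc1cc2c(Nc3cccc(I)c3)ncnc2cc1OC`) keeps the iodo group of compound 1 and differs from it in one place: hydroxymethyl in place of formyl on an aromatic carbon. Among the compounds with values here, no measured pair changes the formyl group. Within the data shown here, the one measured step, a 4.0-fold higher number from compound 1 to compound 2 (0.60 log units; beyond the scatter) with fluoro in place of iodo, is modest and beyond the scatter, but it lies at a different place and serves only as a yardstick for size. In this assay a step of similar size or smaller is therefore expected for this change. The data do not settle the direction, and a slightly higher number is assumed, with no change beyond the scatter a real possibility. The estimated step is a 1.5-fold higher number from compound 1 to compound 3 (0.18 log units; within the scatter) and remains an expectation. Compound 3 is expected at 4500 nM with 1500 nM to 15000 nM as the estimated range.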

Compound 3, half-maximal inhibitory concentration: 9950 nM
Beside the measured number, compound 3's estimate is 2.2-fold (0.34 log units) below it, within the range that was stated.
By their numbers in this assay, from the lowest: compound 1; then compounds 3 and 2 (each within the scatter of the next).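

In this assay, going by these compounds alone, the step of a 3.3-fold higher number from compound 1 to compound 3 (0.52 log units; beyond the scatter) is the first measured change at this position, on the aromatic carbon next to the ring nitrogen, and it shows that exchanging hydroxymethyl for formyl is not silent here: the number moves beyond the scatter in the direction of a weaker inhibitor. The change is small in terms of structure, with the double bond outside aromatic rings leaving and a hydrogen-bond donor entering, yet the step is modest in the same way as the one at the other place, a 4.0-fold higher number from compound 1 to compound 2 (0.60 log units; beyond the scatter) and so this position now counts alongside the iodo-to-fluoro change as one where the read-out responds. Nothing available explains the step, so it stands as an observation without a cause.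

Going by these compounds, with only formyl and hydroxymethyl at this carbon, it remains open whether a carboxylic acid, an aminomethyl group or a plain methyl group would stay close to compound 1 or move further from it. On these data alone, it is also open whether the step seen with the iodo group carries over when the fluoro group of compound 2 is present on the same core.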